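Mirror-image pair for thromboxane receptor binding

The source may hold more compounds than are shown below. What is called first, only, known or untested is meant among the compounds shown, and "the series" means these compounds.

Measured compounds:
- compound 1 `O=C(O)CCc1ccccc1CC1CCC[C@H]1c1nc(C(=O)NCCCCC2CCCCC2)co1` — 4.3 nM
- compound 2 `O=C(O)CCc1ccccc1C[C@@H]1CCC[C@@H]1c1nc(C(=O)NCCCCC2CCCCC2)co1` — 23.8 nM
- compound 3 `O=C(O)CCc1ccccc1C[C@H]1CCC[C@@H]1c1nc(C(=O)NCc2ccc(Cl)cc2)co1` — 3.3 nM

In an assay on cell membranes for binding affinity to thromboxane A2 receptor (Homo sapiens), read by radioligand binding (on this read-out lower numbers stand for tighter binding and higher numbers for weaker binding), compound 3 gives the lowest of the three numbers, but compound 1 lies within the usual scatter of it, and only compound 2 stands clearly apart. Compound 4 `O=C(O)CCc1ccccc1C[C@@H]1CCC[C@H]1c1nc(C(=O)NCc2ccc(Cl)cc2)co1` is the mirror image of compound 3: the two compounds have the same atoms and bonds and differ only in configuration as drawn: 2 of 2 stereo elements differ (all stereocentres are inverted: mirror images); a stereocentre at a saturated ring carbon is drawn R in compound 3 and S in compound 4; a stereocentre at a saturated ring carbon is drawn S in compound 3 and R in compound 4. For the measured compounds named here, the one measured step that bears on configuration, a 5.5-fold higher number from compound 1 to compound 2 (0.74 log units; beyond the scatter), shows that changing the drawn configuration on this core can move the number, though that comparison is clouded because of the fact that one of compounds 1 and 2 is drawn with a defined configuration and the other without, at the place where they differ. Going by the values given here, with that as the only guide, the mirror image is expected to bind less tightly, with a step of a 9.1-fold higher number from compound 3 to compound 4 (0.96 log units; beyond the scatter) in this assay. For compound 4 the expected value is 30 nM, in a range from 5 nM to 200 nM.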

Compound 4, dissociation constant: 0.5 nM
Beside the measured number, compound 4's estimate is 60-fold (1.78 log units) above it; measured number below the stated range.
By their numbers in this assay, from the lowest: compound 4; then compounds 3 and 1 (each within the scatter of the next); then compound 2.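

In this assay, inverting both stereocentres at the saturated ring carbons gives a 6.6-fold lower number from compound 3 to compound 4 (0.82 log units; beyond the scatter), so on this core one mirror image binds more tightly than the other. Unlike the earlier step, this comparison involves no stereocentre drawn without a configuration, and the change in binding can be put down to configuration alone because the pair is a clean one: the fact that compounds 3 and 4 differ only in the configuration as drawn

From the compounds shown here alone, whether the same configuration also gives tighter binding with the other amide side chain remains open. So does the effect on this mirror-image pair of a tetrazole in place of the carboxylic acid.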